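Swapping a triazole for a trifluoromethyl-pyrazole on the same carbon

The compounds below may be only part of what the source reports. "The series", "measured", "known", "first", "only" and "open" are said of these compounds alone.

Compound 1 `FC(F)(F)c1ccc2[nH]c(-c3ccccc3)nc2c1`: 1200 nM
Compound 2 `O=[N+]([O-])c1ccc2nc(-c3ccccc3Cl)[nH]c2c1`: 10700 nM
Compound 3 `FC(F)(F)c1ccc2[nH]c(-c3ccc(-c4nnc[nH]4)cc3)nc2c1`: 3080 nM

In a functional assay for antagonist activity at Neuropeptides B/W receptor type 1 (Homo sapiens), read by cAMP accumulation (on this read-out lower numbers stand for stronger inhibition and higher numbers for weaker inhibition), compound 3 stands second highest of the three numbers; compound 1 lies nearest, with a lower number, and compound 2 furthest, with a higher number. Compound 4 `FC(F)(F)c1ccc2[nH]c(-c3ccc(-c4c[nH]nc4C(F)(F)F)cc3)nc2c1` differs from compound 3 in one place: 3-(trifluoromethyl)-1H-pyrazol-4-yl in place of 4H-1,2,4-triazol-3-yl on an aromatic carbon. For the measured compounds named here, the only measured step that touches this site is a 2.6-fold higher number from compound 1 to compound 3 (0.41 log units; beyond the scatter), which introduced the very group now being replaced. Going by the values given here, no measured pair shows one five-membered aromatic ring exchanged for another, so the direction of the change is open. Compound 4 is therefore expected to stay close to compound 3, with an expected step of a 1.2-fold lower number from compound 3 to compound 4 (0.09 log units; within the scatter). The estimate for compound 4 in this assay is 2500 nM, within a range of 800 nM to 8000 nM.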

Compound 4, half-maximal inhibitory concentration: 1200 nM
Beside the measured number, compound 4's estimate is 2.1-fold (0.32 log units) above it; measured number inside the range.
By their numbers in this assay, from the lowest: compounds 1 and 4 (each within the scatter of the next); then compound 3; then compound 2.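

In this assay the exchange of one five-membered aromatic ring for another gives a 2.6-fold lower number from compound 3 to compound 4 (0.41 log units; beyond the scatter) and so shows that the identity of the ring on this carbon matters. Measured against hydrogen, the pyrazole gives no change at the digits printed from compound 1 to compound 4 (within the scatter) while the triazole gave a 2.6-fold higher number from compound 1 to compound 3 (0.41 log units; beyond the scatter) and so a ring on this carbon does not by itself raise the number. No evidence is available that explains the difference between the two rings. As far as these compounds go, whether an amine or a carboxylic acid on this carbon would bring the number lower than in compound 1 remains open.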